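From 3-fluorophenyl to cyclopentyl on the amine nitrogen

The source may hold more compounds than are shown below. What is called first, only, known or untested is meant among the compounds shown, and "the series" means these compounds.

In a functional assay on MCF7 cells (Homo sapiens) for inhibition, read by sulforhodamine B assay (a higher number here means a weaker inhibitor, a lower number a stronger inhibitor), compound 3 `O=C1C=C(Nc2cccc(F)c2)C(=O)c2c1nc1n2[C@H]2OC[C@@H](O)[C@H]2OC1` gives 5500 nM and compound 2 `O=C1C=C(Nc2ccccc2F)C(=O)c2c1nc1n2[C@H]2OC[C@@H](O)[C@H]2OC1` gives 3640 nM so the two sit level, separated by a 1.5-fold higher number from compound 2 to compound 3 (0.18 log units; within the scatter) and nothing more. In this assay compound 1 `O=C1C=C(NCc2ccccc2)C(=O)c2c1nc1n2[C@H]2OC[C@@H](O)[C@H]2OC1` has a limit, > 8000 nM and not a number.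

Compound 4 `O=C1C=C(NC2CCCC2)C(=O)c2c1nc1n2[C@H]2OC[C@@H](O)[C@H]2OC1` has not yet been measured. It carries cyclopentyl in place of 3-fluorophenyl on an amine nitrogen and so loses the fluorophenyl.

For the measured compounds named here, compound 1, with its benzyl, is the only measured compound without a fluorophenyl on that nitrogen, so its steps are the best guide. They are an at least 2.1-fold lower number from compound 1 to compound 2 (0.34 log units; beyond the scatter) and an at least 1.4-fold lower number from compound 1 to compound 3 (0.16 log units; that floor lies within the scatter) and both are small. Leaving the fluorophenyl behind should therefore run the opposite way, and in this assay a small rise in the number is expected. The expected change is a 1.3-fold higher number from compound 3 to compound 4 (0.10 log units; within the scatter) and it may not clear the scatter. Compound 4 is expected at 7000 nM with an estimated range from 3000 nM to 16000 nM in this measurement.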

Compound 4, half-maximal inhibitory concentration: > 16000 nM
Compound 4 ended at the assay's limit; the forecaster's own chance of this, stated with the estimate: 35%; middle value at least 2.2-fold (0.35 log units) away from the limit.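

Putting cyclopentyl on this amine nitrogen, a ring with nothing aromatic in it, costs activity in this assay, and it does so against both fluorophenyl compounds: an at least 2.9-fold higher number from compound 3 to compound 4 (0.46 log units; beyond the scatter) and an at least 4.3-fold higher number from compound 2 to compound 4 (0.64 log units; beyond the scatter). The earlier compounds shown here held an aromatic ring in every case, so they could not show that a wholly non-aromatic ring here gives a weaker inhibitor than either fluorophenyl group. Compound 4 carries a limit and not a number, so both steps give only a minimum size: the limit of > 16000 nM in this assay, at which 1 of the 4 values shown sits.

The step between compound 1 and compound 4 cannot be read, as both ends are limits. Still open, as far as these compounds go, is whether the aromatic ring or its fluorine counts for more, a question that a plain phenyl and a cyclohexyl on this nitrogen would help to separate.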